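Acetoxy on the side chain of a naphthoquinone core

This account rests on a few compounds, and the source may have more. Where it says the series, first, only, none or still open, it means among the compounds named here.

Measured compounds:
compound 1, `COc1ccc(O)c2c1C(=O)C=C(CCC=C(C)C)C2=O`: 980 nM
compound 2, `COc1ccc(O)c2c1C(=O)C(CCC=C(C)C)=CC2=O`: 6390 nM

In an ADME assay on Vero cells (Chlorocebus sabaeus) for cytotoxicity, read by MTT assay, with a stated time of 48 h (on this read-out higher numbers stand for weaker inhibition and lower numbers for stronger inhibition), compound 1 gives 980 nM and stands at the lowest number of the two measured. Going by the values given here, compound 2 gives 6390 nM in this assay, a gap from compound 1 that lies beyond the usual scatter; no single step between the two is drawn here, so only their two values are compared.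

Compound 3, `COc1ccc(O)c2c1C(=O)C=C([C@H](CC=C(C)C)OC(C)=O)C2=O`, departs from compound 1 by one change: acetoxy in place of hydrogen on a saturated chain carbon bound to a double-bonded ring carbon and a saturated chain carbon. Among the compounds with values here, no measured pair shows a step of this kind, so the size and direction of the step are open. The acetoxy is expected to leave the number near that of compound 1, perhaps modestly higher, within a step that may not exceed the scatter: the expected step is a 1.5-fold higher number from compound 1 to compound 3 (0.18 log units; within the scatter). Compound 3 is accordingly estimated at 1500 nM, with a range from 500 nM to 4500 nM.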

Compound 3, half-maximal inhibitory concentration: 590 nM
Compound 3: middle estimate off by 2.5-fold (0.41 log units), on the high side; low and high end bracket the measured number.
By their numbers in this assay, from the lowest: compounds 3 and 1 (each within the scatter of the next); then compound 2.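

In this assay the change of hydrogen to acetoxy on a saturated chain carbon bound to a double-bonded ring carbon and a saturated chain carbon gives a 1.7-fold lower number from compound 1 to compound 3 (0.22 log units; within the scatter). Going by these compounds alone, this is the first single-place step in the set, and it shows that this chain carbon can carry an acetoxy group without the number moving beyond the scatter. No measurement on hand offers an explanation for this result.

On these data alone, what remains open is whether a free hydroxyl, an amine or a longer ester on this same carbon would also leave the number within the scatter of compound 1. Also open, as far as these compounds go, are the effect of the opposite configuration at this carbon and of the same acetoxy change on compound 2.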